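Adding Bromine to the Phenyl Ring of Compound 2

The source may hold more compounds than are shown below. What is called first, only, known or untested is meant among the compounds shown, and "the series" means these compounds.

Of the compounds shown here, two with a shared core have been tested in a functional assay on NCI-H460 cells (Homo sapiens) for cytotoxicity, read by MTT assay, with a stated time of 72 h; on this read-out higher numbers stand for weaker inhibition and lower numbers for stronger inhibition. Compound 1 `COc1cc2c(Oc3ccc(NC(=O)c4nn(-c5ccc(Br)cc5)c(=O)c5ccccc45)cc3F)ccnc2cc1OCCCN1CCCC1` gives 180 nM, and compound 2 `COc1cc2c(Oc3ccc(NC(=O)c4nn(-c5ccccc5)c(=O)c5ccccc45)cc3F)ccnc2cc1OCCCN1CCCCC1` gives 650 nM. Compound 2 therefore stands at the higher of the two numbers, and its gap to compound 1 lies beyond the usual scatter; the two structures differ in more than one place, so that gap cannot be tied to a single change.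

Compound 3 `COc1cc2c(Oc3ccc(NC(=O)c4nn(-c5ccc(Br)cc5)c(=O)c5ccccc45)cc3F)ccnc2cc1OCCCN1CCCCC1` is not yet measured. It differs from compound 2 by bromo in place of hydrogen on an aromatic carbon, so the change adds a bromine atom to the phenyl ring while the rest of compound 2 is kept.

With no single-change comparison available, only a modest step is expected for this assay, leaning toward a lower number, and possibly none beyond the scatter. For compound 3 the expected step is a 2.2-fold lower number from compound 2 to compound 3 (0.34 log units; beyond the scatter). Compound 3 is thus estimated at 300 nM, within a range from 100 nM to 900 nM.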

Compound 3, half-maximal inhibitory concentration: 410 nM
Estimate against measurement, compound 3: 1.4-fold (0.14 log units) below, within the range that was stated.
By their numbers in this assay, from the lowest: compound 1; then compounds 3 and 2 (each within the scatter of the next).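

In this assay, among these compounds, the change from phenyl to 4-bromophenyl gives a 1.6-fold lower number from compound 2 to compound 3 (0.20 log units; within the scatter), so with the piperidin-1-yl group in place, this bromo group on the aromatic carbon para to a large group produces no step that can be told from repeat-measurement noise. The other single change, piperidin-1-yl in place of pyrrolidin-1-yl on the saturated chain, gives a 2.3-fold higher number from compound 1 to compound 3 (0.36 log units; beyond the scatter), and this modest step does lie beyond the scatter. Nothing shown here offers a measured explanation for either step.

It remains open whether bromo would matter more with pyrrolidin-1-yl at the chain end, since the pair that would test this is absent from the compounds shown. Also open, as far as these compounds go, is how chloro or methoxy on the same ring, or morpholin-4-yl at the chain end, would read in this assay.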